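This account rests on a few compounds, and the source may have more. Where it says the series, first, only, none or still open, it means among the compounds named here.

Working notes on the series

Compound 1 `COc1ccc(CNc2nc([Se]C)nc3ccccc23)cc1` and compound 2 `COc1ccc(CNc2nc([SeH])nc3ccccc23)cc1` carry the same shared core and differ only at the selenium. In a functional assay on HT-29 cells (Homo sapiens) for cytotoxicity, read by MTT assay, with a stated time of 72 h (on this read-out lower numbers stand for stronger inhibition of growth and higher numbers for weaker inhibition of growth), compound 1 gives 73600 nM, and compound 2 gives 71600 nM; the step of a 1.0-fold lower number from compound 1 to compound 2 (0.01 log units; within the scatter) is within the scatter. Compound 3 `C[Se]c1nc([Se]C)c2cccnc2n1` sits on a different core; in this assay compound 3 gives "not determined" (no result reported), so no single number places it among the measured compounds. Compound 4 `C[Se]c1nc(N)c2cccnc2n1` differs from compound 3 by one nitrogen atom in place of a group of 2 heavy atoms (1 carbon, 1 selenium; no ring), on an aromatic carbon. Among the compounds with values here, of the measured steps, only the one from compound 1 to compound 2 touches a selenium group, and it is within the scatter; it does not involve an amino group, so nothing here bears directly on the change to compound 4. Within the data shown here, with no number for compound 3 and no step of this kind, the expectation for compound 4 rests on the level of the measured compounds, both near the weak end of this assay. Compound 4 is therefore expected to give about 60000 nM in this assay, with a wide range from 8000 nM to 300000 nM.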

Compound 4, concentration for 50% growth inhibition: 44100 nM
For compound 4 the middle estimate is 1.4-fold (0.13 log units) above the measured one, and the stated range covers the measured number.
By their numbers in this assay, from the lowest: compounds 4, 2 and 1 (each within the scatter of the next).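

No new step can be read from compound 3 to compound 4: compound 3 has no single number in this assay. The compounds shown leave open how the amino group of compound 4 compares with the group it replaces. No evidence at hand bears on this result.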